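Weighing a 4-methoxyphenyl against a 3-bromophenyl

The source may report more compounds than this note shows. Statements on the series, on what has been measured and on what is new or still open speak of the compounds shown alone.

Of the compounds shown here, three have been measured in a functional assay on M21 cells (Homo sapiens) for antiproliferative activity, read by sulforhodamine B assay, with a stated time of 48 h; on this read-out lower numbers stand for stronger inhibition and higher numbers for weaker inhibition. Compound 1, `CCCCCc1ccc(NS(=O)(=O)c2ccc(N3CCNC3=O)cc2)cc1`, gives 870 nM. Compound 2, `CCc1ccccc1NS(=O)(=O)c1ccc(N2CCNC2=O)cc1`, gives 180 nM. Compound 3, `O=C1NCCN1c1ccc(S(=O)(=O)Nc2cccc(Br)c2)cc1`, gives 59 nM, the lowest of the three numbers, with compound 2 nearest and compound 1 furthest. Among the measured compounds shown here, the single step between compounds that differ in one place is a 3.1-fold lower number from compound 2 to compound 3 (0.48 log units; beyond the scatter), a change in the aryl group on the sulfonamide nitrogen.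

Compound 4, `COc1ccc(NS(=O)(=O)c2ccc(N3CCNC3=O)cc2)cc1`, differs from compound 3 in that same place: 4-methoxyphenyl in place of 3-bromophenyl on a sulfonamide nitrogen. For the measured compounds named here, no measured step leads to a 4-methoxyphenyl, so the size of the change can only be judged loosely. Going by the values given here, the one step that bears on it, a 3.1-fold lower number from compound 2 to compound 3 (0.48 log units; beyond the scatter), shows that swapping the aryl group here moves the number beyond the scatter, and compound 1, which also carries its substituent in the 4-position, gives the highest number of the set at 870 nM. Compound 4 is therefore expected to show a step of a 4.2-fold higher number from compound 3 to compound 4 (0.63 log units; beyond the scatter) in this assay, a higher number than compound 3. The estimate for compound 4 is 250 nM, within a range from 80 nM to 800 nM.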

Compound 4, half-maximal inhibitory concentration: 580 nM
Compound 4: the middle estimate sits 2.3-fold (0.37 log units) below what was measured; low and high end bracket the measured number.
By their numbers in this assay, from the lowest: compound 3; then compound 2; then compounds 4 and 1 (each within the scatter of the next).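

In this assay, among the compounds shown here, the aryl group on the sulfonamide nitrogen proves able to move the number further than the one earlier step showed: 4-methoxyphenyl in place of 3-bromophenyl gives a 9.8-fold higher number from compound 3 to compound 4 (0.99 log units; beyond the scatter), and 4-methoxyphenyl in place of 2-ethylphenyl gives a 3.2-fold higher number from compound 2 to compound 4 (0.51 log units; beyond the scatter). Methoxy in place of pentyl on an aromatic carbon, by contrast, gives a 1.5-fold lower number from compound 1 to compound 4 (0.18 log units; within the scatter), so these two groups cannot be told apart on this read-out despite the difference in chain, and compound 1 and compound 4 alike stand at higher numbers than compound 2, at 180 nM, and compound 3, at 59 nM. Nothing measured alongside these numbers bears on why the aryl groups differ as they do.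

Going by these compounds, it remains open how an unsubstituted phenyl, or a phenyl carrying an amine or a carboxylic acid, would compare with these four groups on the sulfonamide nitrogen. On these data alone, it also remains open whether the low number of compound 3 belongs to the bromine itself, or whether a chlorine or a methyl group in the same place on the ring would give a similar number.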